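The compounds below may be only part of what the source reports. "The series", "measured", "known", "first", "only" and "open" are said of these compounds alone.

Working notes on the series. The read-out throughout is an assay on isolated protein for inhibition of alpha-mannosidase (Canavalia ensiformis), with stated times of 5 min and 20 min, tested at 1 mM; on this read-out higher numbers stand for more inhibition at the one concentration tested (going by the name of the read-out) and lower numbers for less inhibition. Compound 1, `O[C@@H]1[C@H](O)CN[C@H]1Cn1cc(-c2ccccc2)nn1`, gives "not active" (no number reported) in this assay, with no number reported for it. Compound 3, `O[C@@H]1[C@H](O)CN[C@H]1CNC(=S)Nc1ccccc1`, likewise gives "not active" (no number reported) in this assay. Going by the values given here, the only numbered entry is compound 2, `[N-]=[N+]=NC[C@H]1NC[C@@H](O)[C@H]1O`, which gives 43% in this assay. Among the compounds with values here, compound 1 therefore stands among the entries without a number, and no step between two measured compounds is recorded in the set.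

Compound 4, `O[C@H]1[C@@H](O)CN[C@@H]1Cn1cc(-c2ccccc2)nn1`, is the mirror image of compound 1: the two compounds have the same atoms and bonds and differ only in configuration as drawn: 3 of 3 stereo elements differ (all stereocentres are inverted: mirror images); a stereocentre at a saturated ring carbon is drawn S in compound 1 and R in compound 4; a stereocentre at a saturated ring carbon is drawn R in compound 1 and S in compound 4; a stereocentre at a saturated ring carbon is drawn S in compound 1 and R in compound 4. Within the data shown here, no measured pair in the set shows what such an inversion does in this assay, so neither the size nor the direction of the step from compound 1 to compound 4 can be read from the data; the change may leave compound 4 within the scatter of compound 1, or move it either way.

Compound 1 gives "not active" (no number reported) in this assay. The expectation for compound 4 in this assay is a modest value, estimated at 20%, in the range 0% to 50%, with a real chance that again only no activity is reported.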

Compound 4, a percentage reported as inhibition, at one concentration (the size of the read-out at that concentration, not a potency): 60%
Beside the measured number, compound 4's estimate is 40 percentage points below it; measured number outside the range, above it.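

Compound 1 carries no number in this assay, so no step to compound 4 can be read; what is established for the pair is: the fact that compounds 1 and 4 differ only in the configuration as drawn

The compounds shown leave open how large the gap between these mirror images is and which of the inverted stereocentres matters for it.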